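The source may report more compounds than this note shows. Statements on the series, on what has been measured and on what is new or still open speak of the compounds shown alone.

Of the compounds shown here, three built on one shared core have been tested in a functional assay on NCI-H1299 cells (Homo sapiens) for antiproliferative activity, read by XTT assay, with a stated time of 72 h; on this read-out higher numbers stand for weaker inhibition and lower numbers for stronger inhibition. Compound 1 `COc1ccc(-c2cc3ccccc3nc2/C=C/C(=O)c2ccc(OC)cc2OC)cc1` gives 3770 nM. Compound 2 `COc1ccc(-c2cc3ccccc3nc2/C=C/C(=O)c2c(OC)cccc2OC)cc1` gives 4710 nM. Compound 3 `COc1ccc(-c2cc3ccccc3nc2/C=C/C(=O)c2ccc([N+](=O)[O-])cc2)cc1` gives 770 nM. The step of a 1.2-fold higher number from compound 1 to compound 2 (0.10 log units; within the scatter) lies within the scatter, so compound 1 and compound 2 cannot be told apart. The steps of a 4.9-fold lower number from compound 1 to compound 3 (0.69 log units; beyond the scatter) and a 6.1-fold lower number from compound 2 to compound 3 (0.79 log units; beyond the scatter) both lie beyond the scatter, so compound 3 stands lowest of the three numbers and is the strongest inhibitor among them.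

Compound 4 `COc1ccc(-c2cc3ccccc3nc2/C=C/C(=O)c2cccs2)cc1` has not yet been measured. It differs from compound 3 in one place: thiophen-2-yl in place of 4-nitrophenyl on a carbonyl carbon. The measured steps that bear on this are the two that exchanged the group on the same carbonyl carbon, a 4.9-fold lower number from compound 1 to compound 3 (0.69 log units; beyond the scatter) and a 6.1-fold lower number from compound 2 to compound 3 (0.79 log units; beyond the scatter); both were modest, and both moved towards the 4-nitrophenyl group that compound 3 carries. On these data alone, nothing measured shows how a thiophen-2-yl group behaves in that place, and whether it falls as far as the two dimethoxyphenyl groups is unknown. A move away from the group that gave the lowest number is expected to give a modest step towards a higher number, a 2.1-fold higher number from compound 3 to compound 4 (0.32 log units; beyond the scatter). Compound 4 is therefore estimated at 1600 nM, within a range from 500 nM to 5000 nM.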

Compound 4, half-maximal inhibitory concentration: 720 nM
Compound 4: middle estimate off by 2.2-fold (0.35 log units), on the high side, within the range that was stated.
By their numbers in this assay, from the lowest: compounds 4 and 3 (each within the scatter of the next); then compounds 1 and 2 (each within the scatter of the next).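

In this assay, placing thiophen-2-yl instead of 4-nitrophenyl on the carbonyl carbon gives a 1.1-fold lower number from compound 3 to compound 4 (0.03 log units; within the scatter) and so cannot be told apart from no change, which shows that the low number at this position does not depend on the 4-nitrophenyl group: a five-membered aromatic ring with one sulfur atom, and fewer heavy atoms, serves equally well here. Thiophen-2-yl also stands clearly apart from both dimethoxyphenyl groups, with a 6.5-fold lower number from compound 2 to compound 4 (0.82 log units; beyond the scatter) and a 5.2-fold lower number from compound 1 to compound 4 (0.72 log units; beyond the scatter) as the measured steps, so the two dimethoxyphenyl groups are now set against two quite different groups that share a low number. Nothing available explains why these groups separate in this way.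

The groups shown on this carbonyl carbon are all aromatic rings, so it remains open whether a ring is needed there at all, which a cyclohexyl ring or a simple butyl chain could test. On these data alone, it is also open how an unsubstituted phenyl ring or a furan-2-yl ring would compare with thiophen-2-yl and 4-nitrophenyl in this same place.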